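This account rests on a few compounds, and the source may have more. Where it says the series, first, only, none or still open, it means among the compounds named here.

Working notes on the peroxide acid series.

Two compounds carry numbers. Compound 1 `C=C1CCCC(C)(C)C1CC[C@]1(C)CC[C@@H]([C@@H](C)C(=O)O)OO1` has the smaller, monocyclic core; in a functional assay on HT-29 cells (Homo sapiens) for inhibition (a higher number here means a weaker inhibitor of growth, a lower number a stronger inhibitor of growth), compound 1 reaches only the limit of the assay, > 10000 nM, so no number is known for it and the compound sits at the limit of > 10000 nM in this assay, at which 1 of the 2 values shown sits. Compound 2 `C=C1CCC[C@H]2[C@](C)(CC[C@]3(C)CC[C@@H]([C@@H](C)C(=O)O)OO3)[C@@H](C)CC[C@]12C` carries the larger, fused core; in this assay compound 2 gives 1030 nM.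

Compound 3 `C=C1CCCC(C)(C)C1CC[C@@]1(C)CC[C@H]([C@@H](C)C(=O)O)OO1` keeps the atoms and bonds of compound 1. Its difference is the two compounds have the same atoms and bonds; at least one stereo element is drawn with a configuration in one of them and without one in the other: 2 of 4 stereo elements differ; a stereocentre at a saturated ring carbon is drawn R in compound 1 and S in compound 3; a stereocentre at a saturated ring carbon is drawn S in compound 1 and R in compound 3.

For the measured compounds named here, no measured pair in the set differs by a stereochemical change alone, so nothing here tells how such an inversion moves the read-out. With compound 1 known only as a limit, the step from compound 1 to compound 3 cannot be judged against the scatter, and no shift in either direction is assumed; the expected step is a step that the limit leaves unreadable from compound 1 to compound 3. Compound 3 is therefore expected to stay near the limit, at about 12000 nM, within 3000 nM to 40000 nM.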

Compound 3, concentration for 50% growth inhibition: 9260 nM
The estimate for compound 3 lay 1.3-fold (0.11 log units) above the measured number; low and high end bracket the measured number.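

In this assay compound 3 gives 9260 nM as a measured number, so this inverted form of the core of compound 1 reads inside the range of the assay. Compound 1 stands at a limit of > 10000 nM and has no number. Inverting both stereocentres at saturated ring carbons gives an at least 1.0-fold lower number from compound 1 to compound 3 (0.03 log units; that floor lies within the scatter) and the true size of the step stays unread because of that limit: the limit of > 10000 nM in this assay, at which 1 of the 3 values shown sits.

Open, going by these compounds, is whether the same inversion on the core of compound 2 moves its read-out, and whether inverting only one of the two stereocentres does so. Also open, on these data alone, is how a methyl ester or a primary amide in place of the carboxylic acid reads in this assay on either core.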